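Removing a methyl from a phenol ether on the core

The source may report more compounds than this note shows. Statements on the series, on what has been measured and on what is new or still open speak of the compounds shown alone.

Measured so far, in an assay on mitochondria for inhibition of 1,25-dihydroxyvitamin D(3) 24-hydroxylase, mitochondrial (Rattus norvegicus); on this read-out lower numbers stand for stronger inhibition and higher numbers for weaker inhibition:
Compound 1 `COc1ccc2c(c1)CC/C(=C\c1ccccc1C)C2=O` — > 20000 nM
Compound 2 `COc1ccc2c(c1)CCC(Cc1cc(C(F)(F)F)ccc1C(F)(F)F)C2=O` — 4500 nM
Compound 3 `COc1ccc2c(c1)CCC(Cc1ccc(O)cc1)C2=O` — 3500 nM

Three compounds share one core and differ in the group attached to it. For compound 1 the result is a limit of the assay rather than a number: the limit of > 20000 nM in this assay, at which 1 of the 3 values shown sits. Compound 3 gives 3500 nM, one of the two numbers reported. The other number, from compound 2 at 4500 nM, lies within the usual scatter of compound 3, so the two cannot be told apart on this read-out.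

Compound 4 `O=C1c2ccc(O)cc2CCC1Cc1ccc(O)cc1` has not yet been measured. It differs from compound 3 in one place: hydrogen in place of methyl on an oxygen on an aromatic ring. For the measured compounds named here, no pair of measured compounds shows this same change, so its effect cannot be read from the data. The expected step of a 1.2-fold lower number from compound 3 to compound 4 (0.07 log units; within the scatter) is taken to stay within the scatter, in either direction. Compound 4 is therefore estimated at 3000 nM, with a range from 1000 nM to 12000 nM.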

Compound 4, half-maximal inhibitory concentration: 8900 nM
Compound 4: the middle estimate sits 3.0-fold (0.47 log units) below what was measured, within the range that was stated.
By their numbers in this assay, from the lowest: compounds 3, 2 and 4 (each within the scatter of the next, the first and the last beyond it). At a limit, above all of these: compound 1.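

In this assay, for the compounds shown here, the oxygen substituent on the shared core gives the first readable effect of a single change, since no two of the earlier compounds differed in only one place. Going from methoxy to hydroxy, with hydrogen in place of methyl on an oxygen on an aromatic ring, gives a 2.5-fold higher number from compound 3 to compound 4 (0.41 log units; beyond the scatter), a modest step beyond the usual scatter, and here a higher number means weaker inhibition. Nothing measured here bears on why this change has this effect.

The compounds shown leave open whether an ethyl group or a longer chain on that oxygen, or an amine in its place, would lower or raise the number. Going by these compounds alone, they also leave open whether the same change gives a similar step when a different group is attached to the core, as this is the only such pair.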